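Swapping 4-methoxycyclohexyl for 2-(oxan-4-yl)ethyl on the core

The source may report more compounds than this note shows. Statements on the series, on what has been measured and on what is new or still open speak of the compounds shown alone.

In an ADME assay on the whole organism for pharmacokinetics, with Rattus norvegicus as the target, at a dose of 5 mg/kg by the oral route (on this read-out higher numbers stand for higher exposure at the dose given and lower numbers for lower exposure), three compounds sharing one core have been measured. Compound 1 `Cc1nc(-c2nc[nH]n2)ccc1-c1cnc2c(n1)N(CC1CCOCC1)C(=O)CN2` gives 1080 ng.h/mL, compound 2 `COCCN1C(=O)CNc2ncc(-c3ccc(-c4nc[nH]n4)nc3C)nc21` gives 5140 ng.h/mL and compound 3 `CO[C@H]1CC[C@H](N2C(=O)CNc3ncc(-c4ccc(-c5nc[nH]n5)nc4C)nc32)CC1` gives 2930 ng.h/mL. Compound 3 thus holds the second of the three numbers, with a 1.8-fold lower number from compound 2 to compound 3 (0.24 log units; within the scatter) and with a 2.7-fold higher number from compound 1 to compound 3 (0.43 log units; beyond the scatter).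

Compound 4 `Cc1nc(-c2nc[nH]n2)ccc1-c1cnc2c(n1)N(CCC1CCOCC1)C(=O)CN2` differs from compound 3 by having 2-(oxan-4-yl)ethyl in place of 4-methoxycyclohexyl on an amide-type nitrogen in a ring. Within the data shown here, no measured step makes this exact change. The nearest measured relative of compound 4 is compound 1, which carries (oxan-4-yl)methyl at that nitrogen, so the step that bears most is a 2.7-fold higher number from compound 1 to compound 3 (0.43 log units; beyond the scatter). Part of that step is expected to reverse in this assay. The side chain of compound 4 is not the same as that of compound 1, however, and a 4.8-fold higher number from compound 1 to compound 2 (0.68 log units; beyond the scatter) shows that this position can move the number.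

The expected change is a 2.0-fold lower number from compound 3 to compound 4 (0.29 log units; within the scatter). Compound 4 is estimated at 1500 ng.h/mL, with an expected range of 550 ng.h/mL to 4000 ng.h/mL.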

Compound 4, area under the concentration-time curve: 618 ng.h/mL
For compound 4 the middle estimate is 2.4-fold (0.39 log units) above the measured one; the measured number falls inside the stated range.
By their numbers in this assay, from the lowest: compounds 4 and 1 (each within the scatter of the next); then compounds 3 and 2 (each within the scatter of the next).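

In this assay, 2-(oxan-4-yl)ethyl and 4-methoxycyclohexyl hold the same atoms joined differently, yet the exchange brings a 4.7-fold lower number from compound 3 to compound 4 (0.68 log units; beyond the scatter) at this nitrogen, so the arrangement of those atoms matters here and not their count alone. Oxan-4-yl in place of methoxy on the chain brings an 8.3-fold lower number from compound 2 to compound 4 (0.92 log units; beyond the scatter) as the largest step yet seen at this position, whereas the change from (oxan-4-yl)methyl to 2-(oxan-4-yl)ethyl brings a 1.7-fold lower number from compound 1 to compound 4 (0.24 log units; within the scatter) and so shows no effect of chain length that stands clear of the scatter. Across these four compounds, the two carrying oxan-4-yl on a chain, compound 1 and compound 4, both lie beyond the scatter from compound 2 and compound 3.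

As far as these compounds go, whether an amine or a carboxylic acid on this chain, or a longer chain ending in methoxy, would hold the higher exposure remains open. Nothing available explains why these side chains separate as they do.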